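The compounds below may be only part of what the source reports. "The series", "measured", "known", "first", "only" and "open" are said of these compounds alone.

Of the compounds shown here, two built on one shared core have been tested in an ADME assay on L132 cells (Homo sapiens) for inhibition, read by MTT assay, with a stated time of 72 h; on this read-out lower numbers stand for stronger inhibition of growth and higher numbers for weaker inhibition of growth. Compound 1, with the structure `Nc1n[nH]c2cccc(C#Cc3cccc(NC(=O)c4cc(F)cc(C(F)(F)F)c4)c3)c12`, gives > 100000 nM in this assay, which is a limit of the assay and not a number. That entry is the limit of > 100000 nM in this assay, at which 1 of the 2 values shown sits. Going by the values given here, compound 2, with the structure `Nc1n[nH]c2cccc(C#Cc3cccc(C(=O)Nc4cccc(C(F)(F)F)c4)c3)c12`, gives 15300 nM in this assay, and this is the only number obtained so far, so compound 2 stands alone as the one measured point.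

Compound 3, with the structure `CN1CCN(Cc2cc(NC(=O)c3cccc(C#Cc4cccc5[nH]nc(N)c45)c3)cc(C(F)(F)F)c2)CC1`, has not yet been measured in this assay. It differs from compound 2 in one place: (4-methylpiperazin-1-yl)methyl in place of hydrogen on an aromatic carbon. Among the compounds with values here, no step between two measured compounds is available, so there is no measured change to lean on.

The expectation for compound 3 is a step of about a 1.5-fold lower number from compound 2 to compound 3 (0.18 log units; within the scatter) in this assay, that is, a change that would stay within the usual scatter of this kind of measurement rather than a clear move in either direction. Compound 3 is therefore estimated at 10000 nM in this assay, with a range from 3000 nM to 40000 nM.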

Compound 3, concentration for 50% growth inhibition: > 100000 nM
Compound 3 gave a limit, no number (the forecaster's own chance of this, stated with the estimate: 10%); at least 10-fold (1.00 log units) between middle value and limit.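

Going by these compounds alone, this is the first step between two measured compounds. In this assay, (4-methylpiperazin-1-yl)methyl in place of hydrogen on an aromatic carbon, meta to a trifluoromethyl group, gives an at least 6.5-fold higher number from compound 2 to compound 3 (0.81 log units; beyond the scatter). Compound 3 gives > 100000 nM, which is a limit of the assay and not a number. A higher number here means weaker inhibition of growth, so this position is one where a change clearly moves the read-out in that direction, and the full size of the step stays unknown because the value of compound 3 is a limit: the limit of > 100000 nM in this assay, at which 2 of the 3 values shown sit.

A single step cannot show whether the whole (4-methylpiperazin-1-yl)methyl group matters or only one part of it, and a plain methyl, a dimethylaminomethyl group or a morpholin-4-ylmethyl group at the same position would help to separate these possibilities. On these data alone, it also remains open whether a carboxylic acid or a longer chain there would shift the read-out in the same direction, and how such groups would behave at other positions on this ring.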